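Moving from an ether ester to an unsaturated ester

A few compounds are considered here, and "the series" means these few. Any claim that something is new, unique, unknown or untested is made for them only; others in the source may bear on it.

Measured compounds:
- compound 1, `O=C(/C=C/c1ccncc1-c1ccc2ccccc2c1)NC1CC1`: 6180 nM
- compound 2, `NNC(=O)COc1ccncc1-c1ccc2ccccc2c1`: "not determined" (no result reported)
- compound 3, `COC(=O)COc1ccncc1-c1ccc2ccccc2c1`: "not determined" (no result reported)

Three compounds sharing the same core have been examined in a functional assay on HCT-116 cells (Homo sapiens) for inhibition, read by MTT assay, with a stated time of 72 h; on this read-out higher numbers stand for weaker inhibition of growth and lower numbers for stronger inhibition of growth. Compound 1 gives 6180 nM in this assay. Compound 2 returns "not determined" (no result reported) in this assay, and compound 3 likewise returns "not determined" (no result reported) in this assay. Compound 3 therefore has no number of its own to stand on, and compound 2 is the one further entry without a number; only compound 1 anchors the series with a value.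

The compound that has not yet been measured is compound 4, `CCOC(=O)/C=C/c1ccncc1-c1ccc2ccccc2c1`. It differs from compound 3 in one place: 2-(ethoxycarbonyl)ethenyl in place of (methoxycarbonyl)methoxy on an aromatic carbon. Compound 3 has no number in this assay. Among the measured compounds shown here, no step between compound 3 and compound 4 can be stated, and no size or direction of change beyond the scatter can be given for it. For the measured compounds named here, the only guide is compound 1, whose value of 6180 nM comes from a compound that also carries a two-carbon unsaturated linker at the same position.

Compound 4 is estimated at about 6000 nM in this assay, with the range expected to run from 1500 nM to 25000 nM.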

Compound 4, concentration for 50% growth inhibition: 910 nM
Estimate against measurement, compound 4: 6.6-fold (0.82 log units) above; measured number below the stated range.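

Compound 4 gives the series its first step at this position: in this assay, ethoxy in place of cyclopropylamino on the carbonyl carbon produces a 6.8-fold lower number from compound 1 to compound 4 (0.83 log units; beyond the scatter). The 2-(ethoxycarbonyl)ethenyl group on the aromatic carbon opposite the ring nitrogen therefore shows that the unsaturated linker alone does not fix the number, since what ends that linker also shifts the growth-inhibition read-out beyond the scatter. Nothing measured here explains why the ester and the cyclopropyl amide differ in this way.

The steps from compound 2 or compound 3 to compound 4 cannot be read, so the change from (methoxycarbonyl)methoxy to 2-(ethoxycarbonyl)ethenyl, the change named at the outset, remains without a measured size or direction. Also open, from the compounds shown here alone, is how a carboxylic acid, a primary amine or a longer chain at the end of the linker would compare with the ethyl ester of compound 4, and whether the lower number holds for esters beyond this single example.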